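Chloro for hydrogen on the fused-ring core

The compounds below may be only part of what the source reports. "The series", "measured", "known", "first", "only" and "open" are said of these compounds alone.

Working notes on a small series sharing one core, read against an ADME assay on MCF-10A cells (Homo sapiens) for cytotoxicity, read by MTT assay, with a stated time of 48 h; on this read-out higher numbers stand for weaker inhibition and lower numbers for stronger inhibition. Compound 1 `COc1cc(/C=C2\C(=O)Nc3ccc(Cl)cc32)ccc1OCCCN1CC(C)OC(C)C1` carries a chloro on the fused ring and a dimethylmorpholine-ended chain; in this assay compound 1 gives 54700 nM. Compound 2 `COc1cc(/C=C2\C(=O)Nc3ccc(C)cc32)ccc1OCCCN1CC(C)OC(C)C1` has a methyl in place of that chloro, and in this assay compound 2 stands at "not determined" (no result reported), with no result reported. Compound 3 `COc1cc(/C=C2\C(=O)Nc3ccccc32)ccc1OCCCN1CCN(c2ccccn2)CC1` swaps the chain end for a pyridinylpiperazine and leaves the fused ring unsubstituted; in this assay compound 3 likewise stands at "not determined" (no result reported), so it is without a measured position, as is compound 2.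

Compound 4 `COc1cc(/C=C2\C(=O)Nc3ccc(Cl)cc32)ccc1OCCCN1CCN(c2ccccn2)CC1` is to be measured. The difference from compound 3 is chloro in place of hydrogen on an aromatic carbon. Among the measured compounds shown here, no step between measured compounds covers this change, so there is no measured size to lean on. For the measured compounds named here, the only reference with a number is compound 1, which carries the same chloro. Going by the values given here, compound 4 is expected to show no step in this assay beyond the usual scatter; its value is estimated at 50000 nM, within 15000 nM to 150000 nM.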

Compound 4, half-maximal inhibitory concentration: 51300 nM
The estimate for compound 4 lay 1.0-fold (0.01 log units) below the measured number, within the range that was stated.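

Among the compounds shown here, with the chloro held in place on the shared core, the exchange of chain end in this assay can now be sized: 4-(pyridin-2-yl)piperazin-1-yl in place of 2,6-dimethylmorpholin-4-yl gives a 1.1-fold lower number from compound 1 to compound 4 (0.03 log units; within the scatter) as the first measured step. For this pair, the two chain ends therefore read alike on the saturated chain carbon, with the step inside the scatter. No measurement on hand bears on why they read alike.

On these data alone, the steps that would size the chloro itself, or set it against a methyl, cannot be read: compound 2 and compound 3 have no number, so what chloro in place of hydrogen does here stays open. Also open, as far as these compounds go, is whether a fluoro on that aromatic carbon, or a carboxylic acid or primary amine at the chain end, would read the same.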